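Diarylurea series: swapping the aryl on the ring nitrogen

This account rests on a few compounds, and the source may have more. Where it says the series, first, only, none or still open, it means among the compounds named here.

Measured so far:
compound 1, `COc1cc(NC(=O)Nc2cc(Nc3ccc(C(C)(C)C)cc3)ncn2)cc(OC)c1` — 47.7%
compound 2, `CC(C)(C)c1ccc(Nc2cc(NC(=O)Nc3c(Cl)cccc3Cl)ncn2)cc1` — 40%

Among the measured compounds shown here, in a functional assay on NCI-H226 cells (Homo sapiens) for inhibition, read by MTT assay, with a stated time of 48 h, tested at 10 uM (on this read-out higher numbers stand for more inhibition at the one concentration tested (going by the name of the read-out) and lower numbers for less inhibition), compound 1 gives 47.7% and stands highest of the two numbers, though the only other compound, compound 2, gives 40%, a gap within the scatter; the two values therefore cannot be ordered. For the measured compounds named here, the single measured step, a number 7.7 percentage points lower from compound 1 to compound 2 (within the scatter), is the change of the 2,6-dichlorophenyl for the 3,5-dimethoxyphenyl on an amide-type nitrogen, and it lies within the scatter.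

Compound 3, `COc1cc(NC(=O)Nc2cc(Nc3cc(C)cc(F)c3)ncn2)cc(OC)c1`, differs from compound 1 at another place: 3-fluoro-5-methylphenyl in place of 4-(tert-butyl)phenyl on a nitrogen on an aromatic ring. Going by the values given here, no measured step touches this nitrogen, so the one step on file for the series does not bear on the change, and the only guidance is that the one aryl swap seen so far, at the urea end, moved the read-out by less than the scatter. The expectation is therefore a step of a number 9.7 percentage points lower from compound 1 to compound 3 (within the scatter) from compound 1 to compound 3, with a wide range to reflect the absence of any step at this position. Compound 3 is estimated at 38%, within 15% to 60%.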

Compound 3, a percentage reported as inhibition, at one concentration (the size of the read-out at that concentration, not a potency): 35.3%
Estimate against measurement, compound 3: 2.7 percentage points above, and the stated range covers the measured number.
By their numbers in this assay, from the lowest: compounds 3, 2 and 1 (each within the scatter of the next, the first and the last beyond it).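

In this assay, among the compounds shown here, the aryl on the nitrogen on an aromatic ring is the first place where a single swap gives a step beyond the scatter: 3-fluoro-5-methylphenyl in place of 4-(tert-butyl)phenyl gives a number 12.4 percentage points lower from compound 1 to compound 3 (beyond the scatter), a modest step, whereas the swap at the urea end gives a number 7.7 percentage points lower from compound 1 to compound 2 (within the scatter). Both groups at this nitrogen are a six-membered aromatic ring of carbon only with no hydrogen-bond donors or acceptors, so the change lies in the ring's substituents, with 10 heavy atoms leaving and 8 entering, one of them fluorine. Nothing available explains the lower number at this position.

This single pair does not separate the loss of the 4-(tert-butyl) group from the arrival of the fluoro and methyl groups, and plain phenyl or a 4-methylphenyl at this nitrogen would help to tell the two apart. Also open, from the compounds shown here alone, is whether a ring carrying an amine or a morpholine at this nitrogen would give a number on either side of that of compound 1, and whether the steps at the two places add up when both are changed together.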